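A few compounds are considered here, and "the series" means these few. Any claim that something is new, unique, unknown or untested is made for them only; others in the source may bear on it.

For the measured compounds named here, in a functional assay on A549 cells (Homo sapiens) for cytotoxicity, read by resazurin assay, with a stated time of 72 h (on this read-out lower numbers stand for stronger inhibition and higher numbers for weaker inhibition), compound 3 (`COc1cc(/C=C/C(=O)OCCCCCO[N+](=O)[O-])ccc1O`) gives 6390 nM, the lowest of the three numbers so far, against compound 2 (`COc1cc(/C=C/C(=O)OCCCO[N+](=O)[O-])ccc1OCCCO[N+](=O)[O-]`) at 15800 nM and compound 1 (`COc1cc(/C=C/C(=O)OCCCCCCO[N+](=O)[O-])ccc1O`) at 37400 nM. Compound 4 (`COc1cc(/C=C/C(=O)OCCCO[N+](=O)[O-])ccc1O`) shortens the ester side chain of compound 3, with nitrooxy in place of 2-(nitrooxy)ethyl on a saturated chain carbon, three bonds along the chain from an oxygen next to a carbonyl group.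

Going by the values given here, one measured step bears directly on this change: a 5.9-fold lower number from compound 1 to compound 3 (0.77 log units; beyond the scatter). That modest step also shortens the chain and lowers the number, but a single step does not show whether the trend continues. Among the compounds with values here, the other evidence is the only measured compound with the ester chain of compound 4, namely compound 2, which gives 15800 nM, although it also carries a second nitrooxy chain that compound 4 lacks. That value points the opposite way, so a modest rise is expected in this assay, with a fall not excluded. The expected change is a 2.3-fold higher number from compound 3 to compound 4 (0.37 log units; beyond the scatter). For compound 4 the estimated value is 15000 nM, within an expected range of 4000 nM to 60000 nM.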

Compound 4, half-maximal inhibitory concentration: 13200 nM
Estimate against measurement, compound 4: 1.1-fold (0.06 log units) above; the measured number falls inside the stated range.
By their numbers in this assay, from the lowest: compound 3; then compounds 4 and 2 (each within the scatter of the next); then compound 1.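

In this assay, the ester chain does not give a one-way trend: a 2.1-fold higher number from compound 3 to compound 4 (0.32 log units; beyond the scatter), which runs opposite to a 5.9-fold lower number from compound 1 to compound 3 (0.77 log units; beyond the scatter), so the number does not keep falling as this chain shortens, and compound 3 keeps the lowest number among the compounds carrying hydrogen on the oxygen on the aromatic ring. Shortening does not simply undo the earlier gain, however, since there is still a 2.8-fold lower number from compound 1 to compound 4 (0.45 log units; beyond the scatter), leaving the shortest of these chains on the lower side of the longest. For the compounds shown here, the new compound also isolates the second nitrooxy chain for the first time: with a 1.2-fold lower number from compound 2 to compound 4 (0.08 log units; within the scatter), replacing 3-(nitrooxy)propyl with hydrogen on that oxygen leaves the number within the usual scatter, so this chain shows no measurable effect at this ester length.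

No measurement shown here explains why the number responds to chain length in this way. Going by these compounds, it remains open whether an amine or a carboxylic acid in place of nitrooxy on the saturated chain carbon would hold the number of compound 3, and whether 3-(nitrooxy)propyl on the aromatic-ring oxygen would stay as silent with a longer ester chain.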